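The source may report more compounds than this note shows. Statements on the series, on what has been measured and on what is new or still open speak of the compounds shown alone.

Measured so far:
compound 1, `COc1ccc(N/C=C\C(=O)c2cn(-c3ccccc3)nc2-c2ccc(F)cc2)cc1`, 19600 nM in an ADME assay on HaCaT cells (Homo sapiens) for antiproliferative activity, read by MTT assay, with a stated time of 48 h; a higher number here means a weaker inhibitor, a lower number a stronger inhibitor;
compound 2, `COc1ccc(-c2nn(-c3ccccc3)cc2C(=O)/C=C\Nc2ccc(Cl)cc2)cc1`, 20900 nM in this assay.

Both compounds share the same core and both sit in the same weak region of this assay. Compound 2 gives the larger of the two numbers, but the gap to compound 1 is within the scatter, so the two cannot be ranked against each other; they read as one level of weak inhibition.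

The next compound, compound 3, `COc1ccc(N/C=C\C(=O)c2cn(-c3ccccc3)nc2-c2ccc(OC)cc2)cc1`, has not been measured in this assay. It differs from compound 2 in one place: methoxy in place of chloro on an aromatic carbon. For the measured compounds named here, no measured pair shows what such an exchange does, so nothing can be drawn from a recorded step.

Given that compound 1 and compound 2 already agree within the scatter, the exchange in compound 3 is expected to leave the number where it is; the expected step of a 1.0-fold higher number from compound 2 to compound 3 (0.00 log units; within the scatter) is none beyond the scatter. Compound 3 is therefore estimated at 21000 nM in this assay, within a range from 9000 nM to 50000 nM.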

Compound 3, half-maximal inhibitory concentration: > 50000 nM
Compound 3: no number, only a limit (the forecaster's own chance of this, stated with the estimate: 10%); at least 2.3-fold (0.37 log units) between middle value and limit.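

In this assay, for the compounds shown here, the change from chloro to methoxy on the aromatic carbon para to a large group is the first exchange that registers beyond the scatter, with an at least 2.3-fold higher number from compound 2 to compound 3 (0.37 log units; beyond the scatter), whereas the earlier pair gave no readable difference. The fluoro exchange points the same way, with an at least 2.5-fold higher number from compound 1 to compound 3 (0.40 log units; beyond the scatter); compound 1 and compound 2 each keep one halogen and sit together, while compound 3 has methoxy in both of those places and carries no halogen. Compound 3 gives > 50000 nM, which is a limit and not a number, so both steps fix only a minimum size: the limit of > 50000 nM in this assay, at which 1 of the 3 values shown sits.

As far as these compounds go, how far compound 3 really lies from the two halogen compounds stays open, as does whether the loss of the halogen or the entry of the methoxy matters more. A methyl, a hydroxy or a dimethylamino group on the same aromatic carbon would show whether only chloro and fluoro hold the number in the measurable range of this assay.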